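The source may hold more compounds than are shown below. What is called first, only, known or untested is meant among the compounds shown, and "the series" means these compounds.

The measured compounds so far:

compound 1, `Cc1c(F)cc(C(=O)NC2CCCCCC2)c(=O)n1Cc1ccc(F)cc1`; in an assay on U-937 cells for inhibition of Fatty-acid amide hydrolase 1 (Homo sapiens), read by scintillation counting, with a stated time of 15 min (a lower number here means a stronger inhibitor, a higher number a weaker inhibitor), compound 1 gives > 10000 nM, which is a limit of the assay rather than a number.
compound 2, `Cc1c(Cl)cc(C(=O)NC2CCCCCC2)c(=O)n1Cc1ccc(F)cc1`; in this assay compound 2 gives 5900 nM.
compound 3, `Cc1ccc(C(=O)NC2CCCCCC2)c(OCc2ccc(F)cc2)n1`; in this assay compound 3 gives > 10000 nM, again a limit and not a number.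

Within the data shown here, only one pair of these differs in a single place: an at least 1.6-fold lower number from compound 1 to compound 2 (0.22 log units; that floor lies within the scatter). That step is a halogen exchange on a different core, and its floor lies within the scatter, so it says little on its own. Compound 3 stands at the ceiling of what has been measured here, and it shares that position with another compound, since (the limit of > 10000 nM in this assay, at which 2 of the 3 values shown sit).

Compound 4, `Cc1nc(OCc2ccc(F)cc2)c(C(=O)NC2CCCCCC2)cc1-c1ccc(F)cc1`, is built from compound 3 by one change: 4-fluorophenyl in place of hydrogen on an aromatic carbon. Among the measured compounds shown here, no measured step bears on this change; the one step known concerns a halogen swap on another core, and nothing among the measured compounds carries a 4-fluorophenyl group at this place. The expectation therefore rests mostly on where compound 3 stands. Compound 4 is expected to give 8000 nM, within 1500 nM to 30000 nM. That estimate means an expected step of an at least 1.2-fold lower number from compound 3 to compound 4 (0.09 log units; that floor lies within the scatter), with a real chance that the assay again returns only a limit.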

Compound 4, half-maximal inhibitory concentration: > 10000 nM
Compound 4 gave a limit, no number; the forecaster's own chance of this, stated with the estimate: 55%; middle value at least 1.2-fold (0.09 log units) from the limit.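

In this assay compound 4 gives > 10000 nM, a limit of the assay and not a number. Compound 3 also stands at a limit, so no step from compound 3 to compound 4 can be read: the limit of > 10000 nM in this assay, at which 3 of the 4 values shown sit.

The compounds shown leave open whether 4-fluorophenyl in place of hydrogen on this aromatic carbon changes the inhibition at all.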